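Shortening the alkyl linker of a hydroxamic acid by one carbon

The source may hold more compounds than are shown below. What is called first, only, known or untested is meant among the compounds shown, and "the series" means these compounds.

Compound 1 (`C#CCN(C)CCCOc1cc(NC(=O)CCCCCCCC(=O)NO)ccc1Cl`) carries its hydroxamic acid at the end of a saturated chain attached through an amide to the shared core. In an assay on isolated protein for inhibition of histone deacetylase 8 (Homo sapiens), read by fluorescence (on this read-out higher numbers stand for weaker inhibition and lower numbers for stronger inhibition), compound 1 gives 1120 nM, the lowest of the two numbers recorded, although compound 2 (`C#CCN(C)CCCOc1cc(NCc2ccc(C(=O)NO)cc2)ccc1Cl`), which instead presents the hydroxamic acid on a benzylamine arm, gives 1170 nM in this assay, a value within the scatter of compound 1, so no order between the two can be claimed.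

Compound 3 (`C#CCN(C)CCCOc1cc(NC(=O)CCCCCCC(=O)NO)ccc1Cl`) has not yet been measured. It differs from compound 1 in one place: hydroxycarbamoyl in place of (hydroxycarbamoyl)methyl on a saturated chain carbon, six bonds along the chain from a carbonyl carbon, which shortens the saturated chain by a single carbon. For the measured compounds named here, no measured pair in this set shows what such a shortening does, so the expectation for compound 3 rests on compound 1 alone. Compound 3 is expected to give about 850 nM in this assay, a step of a 1.3-fold lower number from compound 1 to compound 3 (0.12 log units; within the scatter) that stays within the scatter, with an estimated range from 300 nM to 2500 nM.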

Compound 3, half-maximal inhibitory concentration: 50 nM
For compound 3 the middle estimate is 17-fold (1.23 log units) above the measured one, outside the stated range (below it).
By their numbers in this assay, from the lowest: compound 3; then compounds 1 and 2 (each within the scatter of the next).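

In this assay, hydroxycarbamoyl in place of (hydroxycarbamoyl)methyl on a saturated chain carbon, six bonds along the chain from a carbonyl carbon, gives a 22-fold lower number from compound 1 to compound 3 (1.35 log units; beyond the scatter), a large step. For the compounds shown here, this shows that the length of the saturated chain carrying the hydroxamic acid strongly affects the read-out, and that even this small edit to the chain can move the number well beyond the scatter, which the earlier compounds, with no step between them, could not show. Nothing measured here bears on why the step is so large.

A single step cannot say how the number follows chain length, so the compounds shown leave open whether a still shorter chain, or a longer chain than that of compound 1, would lower or raise it. They also leave open whether the effect of the shortening would persist with an amine in place of the amide link to the shared core, and whether a carboxylic acid in place of the hydroxamic acid of compound 3 would keep the number low.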